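Swapping a Chain for a Ring on a Shared Core

The source may report more compounds than this note shows. Statements on the series, on what has been measured and on what is new or still open speak of the compounds shown alone.

Compound 1 `Cc1cccc(Oc2ccnc(N3CCC[C@H]3C(=O)NCc3cccnc3)n2)c1`: 0%
Compound 2 `CC(=O)CCCCC(=O)N1CCN(c2nccc(Oc3cccc(C)c3)n2)CC1`: 1%

In an assay on isolated protein for inhibition of MAP kinase-activated protein kinase 2 (Homo sapiens), read by HTRF, tested at 10 uM (a higher number here means more inhibition at the concentration tested (going by the name of the read-out), a lower number less inhibition), compound 1 gives 0% and compound 2 gives 1%. Both numbers sit at the bottom of the scale and lie within the usual scatter of each other, so on what has been measured nothing sets compound 2 apart from compound 1. Compound 3 `Cc1cccc(Oc2ccnc(N3CCN(C(=O)c4c(C)noc4C)CC3)n2)c1` has not yet been measured. It differs from compound 2 in one place: 3,5-dimethyl-1,2-oxazol-4-yl in place of 4-acetylbutyl on a carbonyl carbon. Among the compounds with values here, no measured pair shows what this kind of change does in this assay, so the only guide is the pair of near-zero numbers already seen. The change touches a single group on a carbonyl carbon, and the rest of the molecule stays as in compound 2, which showed no inhibition. The expected step of a number 1 percentage points higher from compound 2 to compound 3 (within the scatter) is therefore taken as none beyond the scatter. Compound 3 is estimated at 2%, with a range from -8% to 12%.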

Compound 3, a percentage reported as inhibition, at one concentration (the size of the read-out at that concentration, not a potency): 0%
Beside the measured number, compound 3's estimate is 2 percentage points above it, and the stated range covers the measured number.
By their numbers in this assay, from the lowest: compounds 1, 3 and 2 (each within the scatter of the next).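

Within the data shown here, the swap of 4-acetylbutyl for 3,5-dimethyl-1,2-oxazol-4-yl on the carbonyl carbon gives the first measured step at this position, and in this assay it reads a number 1 percentage points lower from compound 2 to compound 3 (within the scatter) and so shows no real change. An open chain and a five-membered aromatic ring therefore read alike here, and compound 3 stays at the bottom of the scale with compound 2. Nothing measured here gives a reason for this result (no supporting data are available).

From the compounds shown here alone, what stays open is whether any group on this carbonyl carbon can lift the number off the floor, such as a chain ending in an amine or a carboxylic acid, or a plain phenyl ring. With both values so low, these two compounds also cannot show whether this position matters at all for inhibition.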